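Stereocentre inversion in a tryptamine-piperidine series

A few compounds are considered here, and "the series" means these few. Any claim that something is new, unique, unknown or untested is made for them only; others in the source may bear on it.

Of the compounds shown here, three of a shared core have been measured in an assay on CHO cells for displacement of a labelled ligand from 5-hydroxytryptamine receptor 1D (Homo sapiens); a higher number here means a weaker inhibitor, a lower number a stronger inhibitor. Compound 1 `O[C@H]1Cc2ccccc2C1NC1CCN(CCCc2c[nH]c3ccc(-n4cnnc4)cc23)CC1` gives 37 nM. Compound 2 `c1ccc(C2CCCCN2C2CCN(CCCc3c[nH]c4ccc(-n5cnnc5)cc34)CC2)cc1` gives 1.9 nM. Compound 3 `CC(=O)Nc1ccc([C@H](C)NCC2CCN(CCCc3c[nH]c4ccc(-n5cnnc5)cc34)CC2)cc1` gives 0.6 nM, the lowest number of the three; the gap to compound 2 lies beyond the scatter, and the gap to compound 1 is larger still. Compound 3 therefore stands as the strongest inhibitor among the measured set.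

Compound 4 `CC(=O)Nc1ccc([C@@H](C)NCC2CCN(CCCc3c[nH]c4ccc(-n5cnnc5)cc34)CC2)cc1` has not yet been measured. Relative to compound 3 the change is as follows: the two compounds have the same atoms and bonds and differ only in configuration as drawn: 1 of 1 stereo elements differ; a stereocentre at a saturated chain carbon is drawn S in compound 3 and R in compound 4. The two compounds are mirror images at that one centre and otherwise identical.

Among the compounds with values here, no measured pair in this set differs in configuration only, so there is no directly comparable step. What is known is that compound 3, with the drawn S configuration at this centre, gives 0.6 nM in this assay. Mirror-image pairs in receptor binding frequently differ, and the less favoured form tends to give the higher number; the size of such a gap cannot be read from the present data. For compound 4 a weaker result is therefore expected, with a step of a 5.0-fold higher number from compound 3 to compound 4 (0.70 log units; beyond the scatter) beyond the scatter. The estimate for compound 4 in this assay is 3 nM, within a range of 0.6 nM to 20 nM.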

Compound 4, half-maximal inhibitory concentration: 1.5 nM
For compound 4 the middle estimate is 2.0-fold (0.30 log units) above the measured one; low and high end bracket the measured number.
By their numbers in this assay, from the lowest: compound 3; then compounds 4 and 2 (each within the scatter of the next); then compound 1.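

In this assay, within the data shown here, inverting the stereocentre at the saturated chain carbon gives a 2.5-fold higher number from compound 3 to compound 4 (0.40 log units; beyond the scatter), a direct reading of configuration at this position that compound 1, compound 2 and compound 3 could not give, as they form no such pair. The drawn S form of compound 3 is preferred, but the preference is modest, and the drawn R form keeps a low number: compound 4 gives 1.5 nM, so neither configuration at this centre rules out strong inhibition in this series. The step can be assigned to configuration alone because nothing else separates the pair: the fact that compounds 3 and 4 differ only in the configuration as drawn

As far as these compounds go, the pair gives the direction and size of the preference for this one substitution pattern only, so it remains open whether the same preference would hold with an ethyl group in place of the methyl group at this stereocentre. From the compounds shown here alone, it is equally open whether the gap between the two mirror forms would widen, narrow or reverse if the acetamide were replaced by a nitrile or a carboxylic acid.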